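The source may report more compounds than this note shows. Statements on the series, on what has been measured and on what is new or still open speak of the compounds shown alone.

Two compounds share a core and differ only in the aryl group on the nitrogen attached to the aromatic ring. Compound 1 `CCS(=O)(=O)Nc1cc(-c2ccc3ncnc(Nc4cccc(F)c4)c3c2)cnc1OC` gives 3940 nM in a functional assay on HCT-116 cells (Homo sapiens) for cytotoxicity, read by sulforhodamine B assay, with a stated time of 72 h; on this read-out lower numbers stand for stronger inhibition and higher numbers for weaker inhibition. Compound 2 `CCS(=O)(=O)Nc1cc(-c2ccc3ncnc(Nc4ccc(OC)cc4)c3c2)cnc1OC` gives 3490 nM in this assay, and the step of a 1.1-fold lower number from compound 1 to compound 2 (0.05 log units; within the scatter) shows that exchanging one aryl group for another left the number essentially where it was; the two values sit within the scatter of each other, so neither can be called the stronger.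

Compound 3 `CCS(=O)(=O)Nc1cc(-c2ccc3ncnc(Nc4cccc(C(=O)OC)c4)c3c2)cnc1OC` carries the change (3-(methoxycarbonyl)phenyl in place of 4-methoxyphenyl on a nitrogen on an aromatic ring). Among the measured compounds shown here, the only step that bears on it, a 1.1-fold lower number from compound 1 to compound 2 (0.05 log units; within the scatter), changed a ring substituent on the same aryl group without moving the number beyond the scatter. On that basis compound 3 is expected to show a step of about a 1.0-fold higher number from compound 2 to compound 3 (0.01 log units; within the scatter) in this assay, that is, no change beyond the scatter. The estimate for compound 3 is therefore 3600 nM, within a range from 1200 nM to 11000 nM.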

Compound 3, half-maximal inhibitory concentration: 400 nM
The estimate for compound 3 lay 9.0-fold (0.95 log units) above the measured number, and the stated range ends above it.
By their numbers in this assay, from the lowest: compound 3; then compounds 2 and 1 (each within the scatter of the next).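

The aryl group on this nitrogen is not the indifferent place that compound 1 and compound 2 made it seem: in this assay the exchange of 4-methoxyphenyl for 3-(methoxycarbonyl)phenyl gives an 8.7-fold lower number from compound 2 to compound 3 (0.94 log units; beyond the scatter), well past anything seen before. Swapping only fluoro for methoxycarbonyl on the same aromatic carbon gives a 9.9-fold lower number from compound 1 to compound 3 (0.99 log units; beyond the scatter), a step of like size, so both comparisons single out the methoxycarbonyl-bearing ring as the one with the lower number. Nothing available here explains why this group lowers the number.

The compounds shown leave open whether the drop belongs to the methoxycarbonyl group itself or would also come with a carboxylic acid or an amide on that carbon. A longer ester chain, such as ethoxycarbonyl, is equally untested by these compounds.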